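The source may hold more compounds than are shown below. What is called first, only, known or untested is meant among the compounds shown, and "the series" means these compounds.

The shared core is carried by compound 1, with the structure `CCC1C(=O)N(C)c2cnc(-n3ccc4cc(C(=O)NC(C)C)ccc43)nc2N1c1ccn(C)n1`, and by compound 2, with the structure `CCCNC(=O)c1ccc2c(ccn2-c2ncc3c(n2)N(c2ccn(C)n2)C(CC)C(=O)N3C)c1`. In an assay for inhibition of serine/threonine-protein kinase PLK3 (Homo sapiens), read by FRET and Z'-LYTE, with a stated time of 1 h (a lower number here means a stronger inhibitor, a higher number a weaker inhibitor), compound 1 reaches only a limit of the assay, > 10000 nM. In this assay compound 2 likewise stops at a limit, > 10000 nM. The step that the two limits leave unreadable from compound 1 to compound 2 is unreadable, since both of its ends sit at the limit of > 10000 nM in this assay, at which 2 of the 2 values shown sit. Compound 2 therefore stands at the limit, with no number of its own. Compound 3, `CCCCNC(=O)c1ccc2c(ccn2-c2ncc3c(n2)N(c2ccn(C)n2)C(CC)C(=O)N3C)c1`, differs from compound 2 by methyl in place of hydrogen on a saturated chain carbon, three bonds along the chain from an amide-type nitrogen. Within the data shown here, the only measured step, a step that the two limits leave unreadable from compound 1 to compound 2, concerns the same kind of chain change and gives no readable size, so no step beyond the scatter can be foreseen in either direction in this assay. Compound 3 is expected to stay at the limit, with the step that the limit leaves unreadable from compound 2 to compound 3 taken as essentially nothing. The estimate for compound 3 in this assay is 20000 nM, within 8000 nM to 60000 nM.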

Compound 3, half-maximal inhibitory concentration: > 10000 nM
Compound 3 gave a limit, no number; the forecaster's own chance of this, stated with the estimate: 85%; the middle value is on the limit's open side.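

No new step can be read among compound 1, compound 2 and compound 3, all of which stop at a limit in this assay and give no number: the limit of > 10000 nM in this assay, at which 3 of the 3 values shown sit. The compounds shown leave open whether any chain on the amide-type nitrogen changes the result in this assay at all.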